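Tetrazole Exchanged for a Sulfur-Containing Ring on the Chain

The compounds below may be only part of what the source reports. "The series", "measured", "known", "first", "only" and "open" are said of these compounds alone.

Compound 1 `CCCCCCCOc1ccc(CC[C@](C)(N)CC(=O)O)cc1` — 120 nM
Compound 2 `CCCCCCCOc1ccc(CC[C@](C)(N)CCc2nnn[nH]2)cc1` — 670 nM

Going by the values given here, in a functional assay on CHO cells for agonist activity at sphingosine 1-phosphate receptor 4 (Homo sapiens), read by GTPgammaS binding (a lower number here means that less compound is needed, a higher number that more compound is needed for the effect), compound 2 stands at the higher of the two numbers measured so far; the only step known, a 5.6-fold higher number from compound 1 to compound 2 (0.75 log units; beyond the scatter), separates it from compound 1. Compound 3 `CCCCCCCOc1ccc(CC[C@](C)(N)CCN2CC(=O)NS2(=O)=O)cc1` is not yet measured. It carries a group of 8 heavy atoms (2 carbon, 2 nitrogen, 3 oxygen, 1 sulfur; one five-membered non-aromatic ring with 3 hetero atoms) in place of a group of 5 heavy atoms (1 carbon, 4 nitrogen; one five-membered aromatic ring with 4 hetero atoms), on a saturated chain carbon, three bonds along the chain from an amine nitrogen. Among the compounds with values here, no measured step covers this kind of exchange, so the earlier step offers only a loose guide. A further change of the same order, in the same direction, is expected; compound 3 is estimated at 1200 nM (range 250 nM to 6000 nM), a step of a 1.8-fold higher number from compound 2 to compound 3 (0.25 log units; within the scatter).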

Compound 3, half-maximal effective concentration: 1700 nM
The estimate for compound 3 lay 1.4-fold (0.15 log units) below the measured number; low and high end bracket the measured number.
By their numbers in this assay, from the lowest: compound 1; then compound 2; then compound 3.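

In this assay the non-aromatic sulfur-containing ring brings a 2.5-fold higher number from compound 2 to compound 3 (0.40 log units; beyond the scatter) and so moves the number further from the carboxy compound, with a 14-fold higher number from compound 1 to compound 3 (1.15 log units; beyond the scatter) overall. Both replacements shown at this place therefore give a higher number than the carboxy group, and the step from the tetrazole occurs although the hydrogen-bond donor and acceptor counts stay the same. No measurement at hand accounts for this rise.

As far as these compounds go, whether a phosphonic acid at this place would keep the number of compound 1 stays open. So does how a longer chain on the shared core would shift these steps.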